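Quinazoline-free notes: anilino ring swap in a weak cytotoxic series

The source may report more compounds than this note shows. Statements on the series, on what has been measured and on what is new or still open speak of the compounds shown alone.

Measured so far:
- compound 1, `O=C(CSc1nc(Nc2ccccc2)c2ccccc2n1)Nc1cccc([N+](=O)[O-])c1`: 28100 nM
- compound 2, `C=CC(=O)Nc1cccc(NC(=O)CSc2nc(Nc3ccccc3Cl)c3ccccc3n2)c1`: 20700 nM

In a functional assay on MGC-803 cells (Homo sapiens) for inhibition, read by MTT assay, with a stated time of 72 h (a higher number here means a weaker inhibitor, a lower number a stronger inhibitor), compound 1 gives 28100 nM, and compound 2 gives 20700 nM. Compound 2 carries the lower of the two numbers, but the gap to compound 1 lies within the scatter, so the two are to be read as equivalent; both are weak inhibitors in this assay.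

Compound 3, `C=CC(=O)Nc1cccc(NC(=O)CSc2nc(Nc3ccc(F)cc3)c3ccccc3n2)c1`, differs from compound 2 in one place: 4-fluorophenyl in place of 2-chlorophenyl on a nitrogen on an aromatic ring. The amide side of the shared core is unchanged. For the measured compounds named here, no measured pair in the set separates the effect of a swap on this nitrogen, so there is no step to lean on. The expectation for the step from compound 2 to compound 3 in this assay is small, with no clear direction, and most likely not beyond the scatter: a 1.1-fold higher number from compound 2 to compound 3 (0.03 log units; within the scatter). Compound 3 is accordingly expected at 22000 nM, in the range 8000 nM to 60000 nM.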

Compound 3, half-maximal inhibitory concentration: 8290 nM
Estimate against measurement, compound 3: 2.7-fold (0.42 log units) above; measured number inside the range.
By their numbers in this assay, from the lowest: compound 3; then compounds 2 and 1 (each within the scatter of the next).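

In this assay, the group on this nitrogen does register: 4-fluorophenyl in place of 2-chlorophenyl gives a 2.5-fold lower number from compound 2 to compound 3 (0.40 log units; beyond the scatter), with the amide side of the shared core unchanged. For the compounds shown here, compound 1 and compound 2 differ in more than one place, so their values could not isolate this position, and this pair provides the first step that does, though the series remains in a weak range. Nothing measured here accounts for the size or direction of the step.

From the compounds shown here alone, the halogen and its place on the ring change together in this single step, so it remains open which of the two goes with the lower number. Also open, going by these compounds, is how a methoxy group or an amine on this phenyl ring would read with the amide side kept the same.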